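Cytotoxicity notes: compound 4 expected from compound 2

The source may report more compounds than this note shows. Statements on the series, on what has been measured and on what is new or still open speak of the compounds shown alone.

Measured so far:
compound 1 `COc1ccc(/C=C\c2cc(OC)c(OC)c(OC)c2)cc1OCc1ccc(CN[C@H](C(=O)O)[C@H](C)O)cc1`; in an ADME assay on HEK293 cells (Homo sapiens) for cytotoxicity, read by CCK-8 assay, with a stated time of 48 h (a lower number here means a stronger inhibitor, a higher number a weaker inhibitor), compound 1 gives > 50000 nM, which is a limit of the assay and not a number.
compound 2 `COc1ccc(/C=C\c2cc(OC)c(OC)c(OC)c2)cc1OCc1ccc(CN2CC(C(=O)O)C2)cc1`; in this assay compound 2 gives > 50000 nM, again a limit.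
compound 3 `COc1ccc(/C=C\c2cc(OC)c(OC)c(OC)c2)cc1OCc1ccc(CN2C[C@H](O)C[C@@H]2C(=O)O)cc1`; in this assay compound 3 gives > 50000 nM, also a limit.

Compound 2 stands at the limit, as do both other values shown: the limit of > 50000 nM in this assay, at which 3 of the 3 values shown sit. Because of that no measured step can be read: a step that the two limits leave unreadable from compound 1 to compound 2, a step that the two limits leave unreadable from compound 1 to compound 3, a step that the two limits leave unreadable from compound 2 to compound 3.

Compound 4 `COc1ccc(/C=C\c2cc(OC)c(OC)c(OC)c2)cc1OCc1ccc(CN[C@H](C(=O)O)[C@@H](C)O)cc1` differs from compound 2 at one place: (1-carboxy-2-hydroxypropyl)amino in place of 3-carboxyazetidin-1-yl on a saturated chain carbon bound to an aromatic carbon. Compound 4 and compound 1 share this entering group, differing only in stereochemistry, and compound 1 sits at the limit.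

Hence no step beyond the scatter is expected, a step that the limit leaves unreadable from compound 2 to compound 4 being an estimate of no readable change. Compound 4 is expected at about 100000 nM, within 40000 nM to 300000 nM, and most likely returned only as a limit.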

Compound 4, half-maximal inhibitory concentration: > 50000 nM
Compound 4 gave a limit, no number (the forecaster's own chance of this, stated with the estimate: 90%); the middle value is on the limit's open side.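

In this assay no step can be read between compound 4 and compound 1, compound 2 or compound 3: the limit of > 50000 nM in this assay, at which 4 of the 4 values shown sit.

The compounds shown leave open what number any of them would give in this assay, and whether configuration changes it: the fact that compounds 1 and 4 differ only in the configuration as drawn.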